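Thiourea sulfonamides: ethyl in place of phenyl on the thiourea nitrogen

This account rests on a few compounds, and the source may have more. Where it says the series, first, only, none or still open, it means among the compounds named here.

Compound 1 `Cc1cc(C)n(-c2ccc(S(=O)(=O)NC(=S)NCc3ccccc3)cc2)n1` and compound 2 `Cc1cc(C)n(-c2ccc(S(=O)(=O)NC(=S)Nc3ccccc3)cc2)n1` share a core and differ only in the group on the thiourea nitrogen. In a functional assay on the whole organism (blood, strain albino) with Mus musculus as the target, with stated times of 6 days and 4 h, at a dose of 0.4 mmol/kg by the oral route (a higher number here means more inhibition at the dose given (going by the name of the read-out), a lower number less inhibition), compound 1 gives 0%, and compound 2 gives -3%, the lower of the two numbers, though a number 3 percentage points lower from compound 1 to compound 2 (within the scatter). Compound 3 `CCNC(=S)NS(=O)(=O)c1ccc(-n2nc(C)cc2C)cc1` takes the change (ethyl in place of phenyl on an amide-type nitrogen). Among the measured compounds shown here, the one measured step at this nitrogen stayed within the scatter, and no step to a small alkyl group has been seen; a step of a number 3 percentage points higher from compound 2 to compound 3 (within the scatter) is therefore expected, none beyond the scatter. Compound 3 is estimated at 0%, within -10% to 10%.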

Compound 3, a percentage reported as inhibition, in the whole organism at one dose (the size of the read-out at that dose, not a potency): 0%
For compound 3 middle estimate and measured number coincide at the digits printed; low and high end bracket the measured number.
By their numbers in this assay, from the lowest: compounds 2, 1 and 3 (each within the scatter of the next).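

Ethyl on the amide-type nitrogen reads the same as the aromatic groups in this assay (a number 3 percentage points higher from compound 2 to compound 3 (within the scatter); no change at the digits printed from compound 1 to compound 3 (within the scatter)). Loss of the aromatic ring therefore leaves the read-out within the scatter, and ethyl, phenyl and benzyl cannot be told apart at this nitrogen. Nothing at hand bears on the reason for this. Open, from the compounds shown here alone, is whether a longer chain such as octyl, or a substituent carrying a carboxylic acid or an amine, gives a number beyond the scatter here. Equally open, going by these compounds, is whether any change at this nitrogen moves the number away from zero.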